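A few compounds are considered here, and "the series" means these few. Any claim that something is new, unique, unknown or untested is made for them only; others in the source may bear on it.

Measured so far:
compound 1 `COc1ccc(-c2nc3cc(Cl)c(Cl)cc3[nH]2)cc1` gives 30000 nM in an ADME assay on Vero cells (Chlorocebus sabaeus) for cytotoxicity; on this read-out lower numbers stand for higher toxicity in this test and higher numbers for lower toxicity in this test.
compound 2 `O=C(CN1CCCC1)Nc1ccc(-c2nc3cc(Cl)c(Cl)cc3[nH]2)cc1` gives > 100000 nM in this assay; this is a limit of the assay, not a number.

Compound 2 stands at the limit of > 100000 nM in this assay, at which 1 of the 2 values shown sits; for it only a limit is known, no measured number. Compound 1 gives a number below that limit. Compound 3 `CC(=O)Nc1ccc(-c2nc3cc(Cl)c(Cl)cc3[nH]2)cc1` is not yet measured in this assay. It differs from compound 2 by hydrogen in place of pyrrolidin-1-yl on a saturated chain carbon bound to a carbonyl carbon. Within the data shown here, no step between two measured compounds that differ in one place is available, so the size of the step from compound 2 to compound 3 rests on expectation alone. Compound 3 is expected to show a step of an at least 1.6-fold lower number from compound 2 to compound 3 (0.22 log units; that floor lies within the scatter) in this assay, a modest move toward higher toxicity or none beyond the scatter. Compound 3 is estimated at 60000 nM in this assay, with a range from 20000 nM to 150000 nM.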

Compound 3, half-maximal cytotoxic concentration: > 100000 nM
Compound 3: a limit, no number; the forecaster's own chance of this, stated with the estimate: 40%; at least 1.6-fold (0.22 log units) between middle value and limit.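

In this assay, compound 2 and compound 3 both stand at a limit of the assay, not at a number, so the step between them cannot be read: the limit of > 100000 nM in this assay, at which 2 of the 3 values shown sit. Hydrogen in place of pyrrolidin-1-yl on a saturated chain carbon bound to a carbonyl carbon therefore still leaves the read-out at that limit, so pyrrolidin-1-yl is not required to reach it. Among these compounds, compound 3 also gives the first comparison with compound 1 that differs in one place: acetamido in place of methoxy on an aromatic carbon gives an at least 3.3-fold higher number from compound 1 to compound 3 (0.52 log units; beyond the scatter), a move toward lower toxicity in this test.

On these data alone, how far compound 2 and compound 3 lie past the limit remains open, and with it whether pyrrolidin-1-yl changes the read-out at all. Also open, as far as these compounds go, is whether a free amine or a carboxylic acid in place of acetamido on that aromatic carbon would give a number as high.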